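Removing One Methoxy Group: Compound 2 to Compound 3

The source may report more compounds than this note shows. Statements on the series, on what has been measured and on what is new or still open speak of the compounds shown alone.

Of the compounds shown here, two sharing one core have been tested in a functional assay on OVCAR-3 cells (Homo sapiens) for cytotoxicity, read by sulforhodamine B assay, with a stated time of 48 h, tested at 10 uM; on this read-out higher numbers stand for a weaker effect at the one concentration tested and lower numbers for a stronger effect. Compound 1 `COc1cc(-c2cc(/C=C/C(=O)c3ccc(N)cc3)[nH]n2)cc(OC)c1OC` gives -71%, and compound 2 `COc1ccc(C(=O)/C=C/c2cc(-c3cc(OC)c(OC)c(OC)c3)n[nH]2)cc1OC` gives -91%, the lower of the two numbers and so the stronger effect, reached with a number 20 percentage points lower from compound 1 to compound 2 (beyond the scatter). Compound 3 `COc1ccc(C(=O)/C=C/c2cc(-c3cc(OC)c(OC)c(OC)c3)n[nH]2)cc1` differs from compound 2 in one place: hydrogen in place of methoxy on an aromatic carbon. Going by the values given here, the only measured step swapped the whole aryl group on the carbonyl carbon, so it does not speak directly to the loss of a single methoxy; it shows only that this part of the molecule can shift the read-out by a modest amount. A smaller change of this kind is expected to leave the effect in the same region, perhaps slightly weaker, and for compound 3 the expected step is a number 11 percentage points higher from compound 2 to compound 3 (beyond the scatter). Compound 3 is therefore estimated at -80%, within -100% to -50%.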

Compound 3, a percentage reported as activity, at one concentration (the size of the read-out at that concentration, not a potency): -72%
Compound 3: the middle estimate sits 8 percentage points below what was measured, within the range that was stated.
By their numbers in this assay, from the lowest: compound 2; then compounds 3 and 1 (each within the scatter of the next).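

In this assay, the change from 3,4-dimethoxyphenyl to 4-methoxyphenyl gives a number 19 percentage points higher from compound 2 to compound 3 (beyond the scatter), so one methoxy group alone moves the read-out by more than the usual scatter. With a single group left on that ring, methoxy in place of amino gives a number 1 percentage points lower from compound 1 to compound 3 (within the scatter), so these two groups cannot be told apart in this read-out. Nothing available explains why the second methoxy group matters or why the methoxy and amino compounds read alike.

As far as these compounds go, it remains open whether a hydroxyl group or a fluorine atom in place of the lost methoxy group would restore the stronger effect seen with compound 2. A plain phenyl ring would show what the remaining methoxy group of compound 3 contributes.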